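Chlorofuran swap on the core of compound 2

The compounds below may be only part of what the source reports. "The series", "measured", "known", "first", "only" and "open" are said of these compounds alone.

Among the measured compounds shown here, compound 2 `Clc1ccc(-c2cc(-c3ccoc3)cc(-c3ccsc3)n2)cc1` gives 37600 nM in a functional assay on DU-145 cells (Homo sapiens) for cytotoxicity, in the presence of a further agent that is not named here (on this read-out lower numbers stand for stronger inhibition and higher numbers for weaker inhibition), the higher of the two numbers measured so far; compound 1 `Clc1ccc(-c2cc(-c3cccnc3)nc(-c3ccsc3)c2)o1` gives 21600 nM, and the two lie within the scatter of each other, so no order between them can be read. Compound 3 `Clc1ccc(-c2cc(-c3ccc(Cl)o3)cc(-c3ccsc3)n2)cc1` differs from compound 2 in one place: 5-chlorofuran-2-yl in place of furan-3-yl on an aromatic carbon. For the measured compounds named here, no measured pair shows this change on this core, so its size is not known. Because compound 1 also carries a 5-chlorofuran-2-yl group and gives 21600 nM, compound 3 is expected near that, estimated at 25000 nM within 10000 nM to 60000 nM. The step of a 1.5-fold lower number from compound 2 to compound 3 (0.18 log units; within the scatter) is expected to stay within or only just beyond the scatter.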

Compound 3, half-maximal inhibitory concentration: 19500 nM
Estimate against measurement, compound 3: 1.3-fold (0.11 log units) above; measured number inside the range.
By their numbers in this assay, from the lowest: compounds 3, 1 and 2 (each within the scatter of the next).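

In this assay, 5-chlorofuran-2-yl in place of furan-3-yl opposite the ring nitrogen gives a 1.9-fold lower number from compound 2 to compound 3 (0.29 log units; within the scatter), so no effect of this change can be read at this position. The swap of 4-chlorophenyl in place of pyridin-3-yl on an aromatic carbon gives a 1.1-fold lower number from compound 1 to compound 3 (0.04 log units; within the scatter), and no order can be read there either. No supporting data bear on these results.

As far as these compounds go, whether an amine or a carboxylic acid opposite the ring nitrogen would move the number beyond the scatter remains open. Also open is whether any group at this position separates from the three compounds shown.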